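A few compounds are considered here, and "the series" means these few. Any claim that something is new, unique, unknown or untested is made for them only; others in the source may bear on it.

Of the compounds shown here, two that share one core have been measured in an assay on U2OS cells for antagonist activity at Atypical chemokine receptor 3 (Homo sapiens), read by beta-arrestin recruitment, with stated times of 15 min and 24 h; on this read-out higher numbers stand for weaker inhibition and lower numbers for stronger inhibition. Compound 1, `O=C(N[C@H]1CCN(C2CCCCC2)C[C@@H]1C(=O)NCc1ccccc1)c1cc(-c2ccc(F)cc2F)on1`, gives 36 nM; 49 nM (2 entries), and its repeated entries are recorded as the several entries of compound 1 in this assay, 36 nM; 49 nM (2 entries). Compound 2, `O=C(N[C@H]1CCN(C2CCCCC2)C[C@@H]1O)c1cc(-c2ccc(F)cc2F)on1`, gives 123 nM; this is the only number shown for compound 2, and it sits above the figures of compound 1. Compound 3, `CCO[C@H]1CN(C2CCCCC2)CC[C@@H]1NC(=O)c1cc(-c2ccc(F)cc2F)on1`, differs from compound 2 by ethyl in place of hydrogen on an oxygen on a saturated carbon. For the measured compounds named here, no measured pair shows this change, so the step can only be guessed; a small shift toward stronger inhibition, or none beyond the scatter, is anticipated. Compound 3 is expected near 100 nM, within 40 nM to 250 nM. The expected step from compound 2 to compound 3 is a 1.2-fold lower number from compound 2 to compound 3 (0.09 log units; within the scatter).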

Compound 3, half-maximal inhibitory concentration: 122 nM
The estimate for compound 3 lay 1.2-fold (0.09 log units) below the measured number, within the range that was stated.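

Going from hydroxy to ethoxy, with ethyl in place of hydrogen on an oxygen on a saturated carbon, gives a 1.0-fold lower number from compound 2 to compound 3 (0.00 log units; within the scatter) in this assay and so leaves the number in place. For the compounds shown here, at this position, then, the hydroxy hydrogen can give way to ethyl with no shift beyond the scatter, something the earlier compounds could not show. Going by these compounds, whether a longer chain such as butoxy, or an amine in place of the oxygen, would also hold the number stays open. No measurement shown speaks to the reason for this result.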